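The source may report more compounds than this note shows. Statements on the series, on what has been measured and on what is new or still open speak of the compounds shown alone.

Measured in a functional assay on ECa-109 cells for inhibition, with ECa-109 cell line (Homo sapiens) as the target, read by sulforhodamine B assay; a lower number here means a stronger inhibitor, a higher number a weaker inhibitor:
- Compound 1 `CCOc1ccccc1NC1=CC(=O)c2nc3n(c2C1=O)[C@H]1OC[C@@H](O)[C@H]1OC3`: 4630 nM
- Compound 2 `O=C1C=C(N2CCCCC2)C(=O)c2c1nc1n2[C@H]2OC[C@@H](O)[C@H]2OC1`: > 8000 nM

Compound 2 gives no number in this assay: its > 8000 nM is a limit of the assay. Within the data shown here, compound 1 is the only compound here with a measured number, and no step between measured compounds is available.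

Compound 3 `COc1cccc(NC2=CC(=O)c3nc4n(c3C2=O)[C@H]2OC[C@@H](O)[C@H]2OC4)c1` departs from compound 2 at one place: (3-methoxyphenyl)amino in place of piperidin-1-yl on a double-bonded ring carbon. It carries (3-methoxyphenyl)amino in place of piperidin-1-yl on a double-bonded ring carbon.

A modest gain in inhibition is expected, resting on compound 1 with its 4630 nM. The expected change is an at least 2.0-fold lower number from compound 2 to compound 3 (0.30 log units; that floor lies within the scatter), towards stronger inhibition, though its size is uncertain, as compound 2 offers only a limit. A limit may well be reported again for compound 3.

For compound 3 the estimated value is 4000 nM, with an expected range of 1200 nM to 10000 nM.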

Compound 3, half-maximal inhibitory concentration: 7620 nM
For compound 3 the middle estimate is 1.9-fold (0.28 log units) below the measured one; the range from low to high includes it.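

In this assay, (3-methoxyphenyl)amino in place of piperidin-1-yl on the double-bonded ring carbon gives an at least 1.0-fold lower number from compound 2 to compound 3 (0.02 log units; that floor lies within the scatter), and this step is only a floor because its starting value is a limit: the limit of > 8000 nM in this assay, at which 1 of the 3 values shown sits. Changing the aryl group on the amine nitrogen, 3-methoxyphenyl in place of 2-ethoxyphenyl, gives a 1.6-fold higher number from compound 1 to compound 3 (0.22 log units; within the scatter), so these two aryl groups cannot be told apart in this assay. At this position, therefore, both aryl amines give a measured number, but no gain over piperidin-1-yl beyond the scatter can be claimed.

From the compounds shown here alone, how far the true value of compound 2 lies from that of compound 3 remains open. Also open, going by these compounds, is whether morpholine at this carbon, or a chlorine on the phenyl ring, would move the number beyond the scatter.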